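Working notes: position swap from compound 3 to compound 4

A few compounds are considered here, and "the series" means these few. Any claim that something is new, unique, unknown or untested is made for them only; others in the source may bear on it.

Measured so far:
Compound 1 `CCCCCc1cc(C)c(C(=O)N=C(N)N)cc1S(C)(=O)=O` gives 27 nM in a functional assay for inhibition of sodium/hydrogen exchanger (Oryctolagus cuniculus); a higher number here means a weaker inhibitor, a lower number a stronger inhibitor.
Compound 2 `Cc1cc(OCc2ccccc2)c(S(C)(=O)=O)cc1C(=O)N=C(N)N` gives 28 nM in this assay.
Compound 3 `COc1cc(C)c(C(=O)N=C(N)N)cc1S(C)(=O)=O` gives 16 nM in this assay.

Compound 3 has the lowest of the three numbers, but its separation from compound 1 is a 1.7-fold lower number from compound 1 to compound 3 (0.23 log units; within the scatter) and from compound 2 is a 1.8-fold lower number from compound 2 to compound 3 (0.24 log units; within the scatter), both inside the scatter, so no ordering among the three can be claimed.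

The next compound, compound 4 `Cc1cc(N2CCC(N)CC2)c(S(C)(=O)=O)cc1C(=O)N=C(N)N`, is not yet measured. Its change from compound 3 is 4-aminopiperidin-1-yl in place of methoxy on an aromatic carbon. All three measured steps change the group at this same aromatic carbon: a 1.0-fold higher number from compound 1 to compound 2 (0.02 log units; within the scatter), a 1.7-fold lower number from compound 1 to compound 3 (0.23 log units; within the scatter) and a 1.8-fold lower number from compound 2 to compound 3 (0.24 log units; within the scatter). None of them reaches beyond the scatter, although the groups tried so far differ widely in size and shape. Among the measured compounds shown here, the 4-aminopiperidin-1-yl group brings a ring and a hydrogen-bond donor, which none of the earlier groups at this carbon did, so the earlier steps are only a loose guide. On what is known, the expected step in this assay is a 1.4-fold higher number from compound 3 to compound 4 (0.14 log units; within the scatter), that is, nothing clearly beyond the scatter. Compound 4 is therefore estimated at 22 nM, with a range of 8 nM to 70 nM.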

Compound 4, half-maximal inhibitory concentration: 9.8 nM
Beside the measured number, compound 4's estimate is 2.2-fold (0.35 log units) above it; the range from low to high includes it.
By their numbers in this assay, from the lowest: compounds 4, 3, 1 and 2 (each within the scatter of the next, the first and the last beyond it).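

Steps beyond the scatter in this assay now appear at the aromatic carbon ortho to a methylsulfonyl group, with a 2.9-fold lower number from compound 2 to compound 4 (0.46 log units; beyond the scatter) and with a 2.8-fold lower number from compound 1 to compound 4 (0.44 log units; beyond the scatter) both modest, whereas no earlier change at this carbon left the scatter. Against methoxy the picture differs, with a 1.6-fold lower number from compound 3 to compound 4 (0.21 log units; within the scatter) staying inside it, so 4-aminopiperidin-1-yl, with its non-aromatic ring, its hydrogen-bond donor and its larger count of heavy atoms, is accepted at this carbon without a loss but cannot be ranked ahead of methoxy. Nothing available here bears on why these numbers differ.

The ring and the amine enter together in compound 4, so the compounds shown do not tell which of the two goes with the lower number, and a plain piperidin-1-yl group or an open aminoethoxy chain at this carbon would separate them. Also open, on these data alone, is whether a morpholine ring, or a carboxylic acid in place of the amine on the piperidine ring, would give a step from compound 3 that leaves the scatter.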